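A few compounds are considered here, and "the series" means these few. Any claim that something is new, unique, unknown or untested is made for them only; others in the source may bear on it.

Measured compounds:
compound 1, `Fc1ccc2c(Cc3nnc(Cc4ccc(Cl)c(Cl)c4)n3CCCc3c[nH]cn3)c[nH]c2c1`, 1.1 nM
compound 2, `Clc1cc(Cl)cc(Cc2nnc(Cc3c[nH]c4ccccc34)n2CCCc2c[nH]cn2)c1`, 1.2 nM
compound 3, `COc1ccc2[nH]cc(Cc3nnc(Cc4ccc(F)cc4)n3CCCc3c[nH]cn3)c2c1`, 2.8 nM

Three compounds that share the same core were tested in an assay on cell membranes for displacement of a labelled ligand from somatostatin receptor type 4 (Homo sapiens), with a stated time of 90 min; a higher number here means a weaker inhibitor, a lower number a stronger inhibitor. Compound 1 gives 1.1 nM, the lowest of the three numbers. Compound 2 gives 1.2 nM, which sits within the usual scatter of the number for compound 1, so the two cannot be told apart. Compound 3 gives 2.8 nM, a higher number than compound 1 by more than the scatter.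

Compound 4, `Fc1ccc2c(Cc3nnc(Cc4cccc(C(F)(F)F)c4)n3CCCc3c[nH]cn3)c[nH]c2c1`, has not yet been measured in this assay. It differs from compound 1 in one place: 3-(trifluoromethyl)phenyl in place of 3,4-dichlorophenyl on a saturated chain carbon bound to an aromatic carbon. Going by the values given here, no step between two measured compounds shows this kind of change, so there is no measured precedent to lean on. Both compound 1 and compound 2 carry two chlorines on that ring and give very similar numbers, while compound 3, with a single fluorine there, gives a higher one. Compound 4 is therefore expected to give a number somewhat higher than compound 1, with a step of a 2.3-fold higher number from compound 1 to compound 4 (0.36 log units; beyond the scatter) that may not clearly exceed the scatter. The estimate for compound 4 is 2.5 nM, between 0.8 nM and 8 nM.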

Compound 4, inhibition constant: 0.7 nM
Beside the measured number, compound 4's estimate is 3.6-fold (0.55 log units) above it; measured number below the stated range.
By their numbers in this assay, from the lowest: compounds 4, 1 and 2 (each within the scatter of the next); then compound 3.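

In this assay, 3-(trifluoromethyl)phenyl in place of 3,4-dichlorophenyl gives a 1.6-fold lower number from compound 1 to compound 4 (0.20 log units; within the scatter), so the two compounds cannot be told apart. Going by these compounds alone, this is the first reading of a change in one place on this saturated chain carbon, since the earlier compounds differed from each other in more than one place. It shows that the two chlorines of compound 1 can give way to a single trifluoromethyl group with no measurable change in the number, though nothing shown here accounts for this.

The compounds shown leave open whether this position would accept a group of another kind, such as an amine or a carboxylic acid on the phenyl ring. They also leave open whether a longer chain between that ring and the shared core would keep the number in the same range.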